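Trading a chloro for hydrogen on compound 2

The source may report more compounds than this note shows. Statements on the series, on what has been measured and on what is new or still open speak of the compounds shown alone.

In a functional assay on A549 cells (Homo sapiens) for antiproliferative activity, read by MTT assay, with a stated time of 48 h (a lower number here means a stronger inhibitor, a higher number a weaker inhibitor), compound 2 `Cc1ccc(C(=O)/C=C/c2cc(Cl)cc(Cl)c2Oc2c([N+](=O)[O-])cc(C(F)(F)F)cc2[N+](=O)[O-])cc1` gives 10.1 ug/mL, the same number as compound 1 `Cc1ccc(C(=O)/C=C/c2cc(Br)cc(Br)c2Oc2c([N+](=O)[O-])cc(C(F)(F)F)cc2[N+](=O)[O-])cc1` at 10.1 ug/mL. Compound 3 `Cc1ccc(C(=O)/C=C/c2cccc(Br)c2Oc2c([N+](=O)[O-])cc(C(F)(F)F)cc2[N+](=O)[O-])cc1` gives 6.85 ug/mL, which lies within the scatter of both. Compound 4 `Cc1ccc(C(=O)/C=C/c2cccc(Cl)c2Oc2c([N+](=O)[O-])cc(C(F)(F)F)cc2[N+](=O)[O-])cc1` has not been measured yet. It differs from compound 2 by one swap, hydrogen in place of chloro on an aromatic carbon. Among the compounds with values here, one measured step bears on this, the same swap with bromo leaving, and it is small: a 1.5-fold lower number from compound 1 to compound 3 (0.17 log units; within the scatter). No step beyond the scatter is therefore expected in this assay, though a slightly lower number is possible. The estimated change is a 1.4-fold lower number from compound 2 to compound 4 (0.16 log units; within the scatter). For compound 4 the expected value is 7 ug/mL, with a range from 4 ug/mL to 12.5 ug/mL.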

Compound 4, half-maximal inhibitory concentration: 0.95 ug/mL
Estimate against measurement, compound 4: 7.4-fold (0.87 log units) above; the whole stated range lies above it.
By their numbers in this assay, from the lowest: compound 4; then compounds 3, 1 and 2 (each within the scatter of the next).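

In this assay, removing a chloro from this position gives an 11-fold lower number from compound 2 to compound 4 (1.03 log units; beyond the scatter), whereas the same swap with bromo leaving gave only a 1.5-fold lower number from compound 1 to compound 3 (0.17 log units; within the scatter), so the outcome of emptying this position depends on the halogen involved. With this position already empty, the change of the remaining halogen matters too, with a 7.2-fold lower number from compound 3 to compound 4 (0.86 log units; beyond the scatter). Nothing shown explains this difference between chloro and bromo. Whether the gain requires a halogen at the remaining site stays open, since no compound shown has hydrogen there. How a methoxy group or an amine would behave at either site is also unknown.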